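The compounds below may be only part of what the source reports. "The series", "measured", "known", "first", "only" and "open" are said of these compounds alone.

Compound 1 `COc1ccc2c(=O)c(/C=C/C(=O)Nc3cccc(Cl)c3)coc2c1` gives 470 nM in a functional assay on A549 cells (Homo sapiens) for inhibition, read by MTT assay, with a stated time of 48 h; on this read-out higher numbers stand for weaker inhibition and lower numbers for stronger inhibition.
Compound 2 `COc1ccc2c(=O)c(/C=C/C(=O)NCc3ccccc3)coc2c1` gives 11800 nM in this assay.
Compound 3 `COc1ccc2c(=O)c(/C=C/C(=O)NCc3ccc(F)cc3)coc2c1` gives only a limit of the assay, > 100000 nM.

Compound 1 holds the lowest of the two numbers; its nearest neighbour is compound 2, reached by a 25-fold higher number from compound 1 to compound 2 (1.40 log units; beyond the scatter). Compound 4 `COc1ccc2c(=O)c(/C=C/C(=O)Nc3ccccc3C)coc2c1` differs from compound 1 by 2-methylphenyl in place of 3-chlorophenyl on an amide-type nitrogen. Neither measured step tests this kind of change: a 25-fold higher number from compound 1 to compound 2 (1.40 log units; beyond the scatter) and an at least 210-fold higher number from compound 1 to compound 3 (2.32 log units; beyond the scatter) both replace the aryl group on the amide-type nitrogen with a benzyl group, whereas compound 4 keeps an aryl group there and only trades one substituent for another. Compound 4 is therefore expected to stay far nearer to compound 1 than compound 2 did, with a step of a 3.2-fold higher number from compound 1 to compound 4 (0.50 log units; beyond the scatter), and its value in this assay is estimated at 1500 nM, between 300 nM and 8000 nM.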

Compound 4, half-maximal inhibitory concentration: 23400 nM
The estimate for compound 4 lay 16-fold (1.19 log units) below the measured number, outside the stated range (above it).
By their numbers in this assay, from the lowest: compound 1; then compounds 2 and 4 (each within the scatter of the next). At a limit, above all of these: compound 3.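

Keeping an aryl group on the amide-type nitrogen does not by itself hold the number low: 2-methylphenyl in place of 3-chlorophenyl gives a 50-fold higher number from compound 1 to compound 4 (1.70 log units; beyond the scatter). Nor does this aryl group separate from benzyl, with a 2.0-fold higher number from compound 2 to compound 4 (0.30 log units; within the scatter). The remaining step, an at least 4.2-fold lower number from compound 3 to compound 4 (0.63 log units; beyond the scatter), is read against a limit of the assay: the limit of > 100000 nM in this assay, at which 1 of the 4 values shown sits.

Going by these compounds, the change swaps both the substituent and where it sits, so which of the two matters stays open. On these data alone, how a plain phenyl or a methoxyphenyl group on that nitrogen would read also remains open.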